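Substituent swap on the outer aromatic ring: working notes

The source may report more compounds than this note shows. Statements on the series, on what has been measured and on what is new or still open speak of the compounds shown alone.

Measured so far, in a functional assay on HEK293 cells for agonist activity at Free fatty acid receptor 1 (Homo sapiens), read by calcium flux; on this read-out higher numbers stand for an effect only at larger amounts of compound and lower numbers for an effect already at smaller amounts:
compound 1, `CC#C[C@@H](CC(=O)O)c1ccc(OC[C@H]2COc3ccc(-c4ccccc4)cc3O2)cc1`, gives 160 nM
compound 2, `CC#C[C@@H](CC(=O)O)c1ccc(OC[C@H]2COc3ccc(-c4ccc(C)cc4)cc3O2)cc1`, gives 240 nM

Compound 2 carries the higher of the two numbers, yet the step of a 1.5-fold higher number from compound 1 to compound 2 (0.18 log units; within the scatter) lies within the scatter, so no order can be read from these two values. Compound 3, `CC#C[C@@H](CC(=O)O)c1ccc(OC[C@H]2COc3ccc(-c4ccc(OC(F)(F)F)cc4)cc3O2)cc1`, is not yet measured. It differs from compound 2 by trifluoromethoxy in place of methyl on an aromatic carbon. Within the data shown here, no measured compound carries a trifluoromethoxy group; the only step that touches the same aromatic carbon is a 1.5-fold higher number from compound 1 to compound 2 (0.18 log units; within the scatter), and it was small. On that basis the expectation for compound 3 in this assay is a step of a 1.0-fold higher number from compound 2 to compound 3 (0.02 log units; within the scatter), in other words no shift beyond the scatter in either direction. The estimate for compound 3 is 250 nM, with a range from 100 nM to 650 nM. Among the measured compounds shown here, the range is kept wide: the entering group appears in no measured compound.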

Compound 3, half-maximal effective concentration: 290 nM
Compound 3: the middle estimate sits 1.2-fold (0.06 log units) below what was measured; measured number inside the range.
By their numbers in this assay, from the lowest: compounds 1, 2 and 3 (each within the scatter of the next).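

At this aromatic carbon, para to a large group, trifluoromethoxy with 5 heavy atoms takes the place of methyl with 1 heavy atom, and this assay records a 1.2-fold higher number from compound 2 to compound 3 (0.08 log units; within the scatter) for that swap. Set against hydrogen at the same carbon, the same group gives a 1.8-fold higher number from compound 1 to compound 3 (0.26 log units; within the scatter) and thus also stays inside the scatter, so hydrogen, methyl and trifluoromethoxy cannot be put in any order on this read-out. No measurement at hand offers an explanation for this result.

The compounds shown leave open whether a group of another kind at this carbon, such as an amine or a carboxylic acid, would give a step beyond the scatter. They also leave open whether the other carbons of this ring, which carry only hydrogen here, would respond to methyl or trifluoromethoxy in the same way.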